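The source may hold more compounds than are shown below. What is called first, only, known or untested is meant among the compounds shown, and "the series" means these compounds.

Compound 1 `O=C1Nc2ccc(Br)cc2/C1=N/NC(=S)N/N=C/c1c(Cl)cccc1Cl` and compound 2 `Cc1ccc2c(c1)/C(=N/NC(=S)N/N=C/c1c(Cl)cccc1Cl)C(=O)N2` share a core and differ in one place, and the difference is methyl in place of bromo on an aromatic carbon. In a functional assay on HeLa cells (Homo sapiens) for inhibition, read by MTT assay (on this read-out lower numbers stand for stronger inhibition and higher numbers for weaker inhibition), compound 1 gives 3530 nM, while compound 2 gives 1790 nM, so that a 2.0-fold lower number from compound 1 to compound 2 (0.29 log units; within the scatter).

Compound 3 `COc1ccc(/C=N/NC(=S)N/N=C2\C(=O)Nc3ccc(Br)cc32)c(OC)c1` carries a different core, and how it differs from the core of compound 1 is not broken down here. In this assay compound 3 gives only a limit, > 50000 nM; the evidence for this is the limit of > 50000 nM in this assay, at which 1 of the 3 values shown sits.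

Compound 4 `COc1ccc(/C=N/NC(=S)N/N=C2\C(=O)Nc3ccc(C)cc32)c(OC)c1` has not yet been measured. It differs from compound 3 by methyl in place of bromo on an aromatic carbon, which is the same change as that from compound 1 to compound 2, made at the same place. The earlier step was within the scatter, and compound 3 itself gave only a limit, so compound 4 is expected to show a step that the limit leaves unreadable from compound 3 to compound 4, a step of about the same size as the earlier one, resting on the step of a 2.0-fold lower number from compound 1 to compound 2 (0.29 log units; within the scatter). Compound 4 is therefore estimated at 60000 nM in this assay, with a likely range from 20000 nM to 200000 nM, and most probably reported as a limit again.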

Compound 4, half-maximal inhibitory concentration: > 50000 nM
Compound 4: only a limit was reported (the forecaster's own chance of this, stated with the estimate: 70%); the middle value lies beyond the limit too.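

Compound 3 and compound 4 are both reported only as limits in this assay, so no step between them can be read: the limit of > 50000 nM in this assay, at which 2 of the 4 values shown sit.

The compounds shown leave open how far the true numbers of compound 3 and compound 4 lie beyond that limit, and whether methyl in place of bromo on an aromatic carbon shifts the number at all on the core of compound 3.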